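From iodo to phenyl on a shared nucleoside core

A few compounds are considered here, and "the series" means these few. Any claim that something is new, unique, unknown or untested is made for them only; others in the source may bear on it.

Of the compounds shown here, three of this set have been measured. Compound 1 `Nc1nc(N)c2c(-c3ccsc3)cn([C@@H]3O[C@H](CO)[C@@H](O)[C@H]3O)c2n1` gives in a functional assay on HCT-116 cells (Homo sapiens), read by MTT assay, with a stated time of 72 h (a higher number here means a weaker inhibitor, a lower number a stronger inhibitor), only a limit, > 20000 nM. Compound 3 `Nc1nc(N)c2c(-c3ccoc3)cn([C@@H]3O[C@H](CO)[C@@H](O)[C@H]3O)c2n1` likewise gives only a limit in this assay, > 20000 nM. Going by the values given here, the one step between them, a step that the two limits leave unreadable from compound 1 to compound 3, therefore cannot be read. Compound 2 `COc1ncnc2c1c(I)cn2[C@@H]1O[C@H](CO)[C@@H](O)[C@H]1O` also reaches only a limit in this assay, > 20000 nM, so it stands where every measured value of the set sits: the limit of > 20000 nM in this assay, at which 3 of the 3 values shown sit.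

Compound 4 `COc1ncnc2c1c(-c1ccccc1)cn2[C@@H]1O[C@H](CO)[C@@H](O)[C@H]1O` differs from compound 2 in one place: phenyl in place of iodo on an aromatic carbon. Among the compounds with values here, no measured step concerns phenyl in place of iodo, and the single measured step in the set is unreadable. The numbers give no footing for a direction, and a further limit for compound 4 remains the most plausible outcome.

Compound 4 is therefore expected to give about 20000 nM in this assay, within 5000 nM to 60000 nM. This amounts to an expected step of a number no higher from compound 2 to compound 4 (the limit leaves the size open), that is none beyond the scatter.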

Compound 4, half-maximal inhibitory concentration: > 20000 nM
Compound 4: no number, only a limit; the forecaster's own chance of this, stated with the estimate: 70%; the middle value lies on the limit itself.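

In this assay compound 4 gives only a limit (> 20000 nM). Compound 2 also stands at a limit, so the step between compound 2 and compound 4 cannot be read. The compounds shown leave open whether any change on these cores gives a measurable value in this assay at all: the limit of > 20000 nM in this assay, at which 4 of the 4 values shown sit.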